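This account rests on a few compounds, and the source may have more. Where it says the series, first, only, none or still open, it means among the compounds named here.

Compound 1 `COc1cc(OCc2csc(-c3ccc(C(F)(F)F)cc3)n2)c2cc(-c3cn4nc(OC)sc4n3)oc2c1`: 1.3 nM
Compound 2 `COc1cc(OCc2csc(-c3cccc(C(=O)N(C)C)c3)n2)c2cc(-c3cn4nc(OC)sc4n3)oc2c1`: 0.8 nM
Compound 3 `COc1cc(OCc2csc(-c3ccc(OC)nc3)n2)c2cc(-c3cn4nc(OC)sc4n3)oc2c1`: 0.8 nM

In a functional assay on HEK293 cells for antagonist activity at proteinase-activated receptor 4 (Homo sapiens), read by FLIPR and calcium flux, with a stated time of 30 min (a higher number here means a weaker inhibitor, a lower number a stronger inhibitor), compound 3 stands level with compound 2 at the digits shown, the two together giving the lowest numbers of the three, while compound 1 is the furthest away, a 1.6-fold lower number from compound 1 to compound 3 (0.21 log units; within the scatter). Compound 4 `COc1cc(OCc2csc(-c3ccccc3)n2)c2cc(-c3cn4nc(OC)sc4n3)oc2c1` differs from compound 3 in one place: phenyl in place of 6-methoxypyridin-3-yl on an aromatic carbon. Among the compounds with values here, three measured steps bear on this change, a 1.6-fold lower number from compound 1 to compound 2 (0.21 log units; within the scatter), a 1.6-fold lower number from compound 1 to compound 3 (0.21 log units; within the scatter) and no change at the digits printed from compound 2 to compound 3 (within the scatter), and all three lie within the scatter. Each exchange of the group on this aromatic carbon has thus left this assay essentially unmoved, so the expected step is a 1.9-fold higher number from compound 3 to compound 4 (0.27 log units; within the scatter), with nothing beyond the scatter. Compound 4 is accordingly estimated at 1.5 nM in this assay, within a range from 0.5 nM to 5 nM.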

Compound 4, half-maximal inhibitory concentration: 0.3 nM
Compound 4: the middle estimate sits 5.0-fold (0.70 log units) above what was measured; measured number below the stated range.
By their numbers in this assay, from the lowest: compound 4; then compounds 2, 3 and 1 (each within the scatter of the next).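

In this assay, within the data shown here, phenyl without a substituent is the first group on this aromatic carbon to move the number beyond the scatter (a 2.7-fold lower number from compound 3 to compound 4 (0.43 log units; beyond the scatter)), (a 2.7-fold lower number from compound 2 to compound 4 (0.43 log units; beyond the scatter)), (a 4.3-fold lower number from compound 1 to compound 4 (0.64 log units; beyond the scatter)). The three substituted rings lie within the scatter of one another, so here losing the substituent mattered more than exchanging it. No measurement shown explains this gain. Going by these compounds, it remains open whether the gain requires a bare phenyl or would survive a fluorine or methyl on that ring. A pyridine ring without its methoxy group would also separate the ring nitrogen's contribution from the substituent's.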